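Urea and Thiourea Analogues Compared on Rat Aorta

A few compounds are considered here, and "the series" means these few. Any claim that something is new, unique, unknown or untested is made for them only; others in the source may bear on it.

Compound 1, `CC1(C)CC(NC(=S)Nc2ccc(C#N)cc2)c2cc(NS(C)(=O)=O)ccc2O1`, gives 11600 nM in a functional assay on thoracic aorta (Rattus norvegicus) for inhibition; on this read-out higher numbers stand for an effect only at larger amounts of compound and lower numbers for an effect already at smaller amounts.
Compound 2, `CC1(C)CC(NC(=S)Nc2cccc(Cl)c2)c2cc(NS(C)(=O)=O)ccc2O1`, gives 9800 nM.
Compound 3, `CC1(C)CC(NC(=O)Nc2ccc(C#N)cc2)c2cc(NS(C)(=O)=O)ccc2O1`, gives 19800 nM.

Compound 3 stands highest of the three in this assay. Against compound 1 its value is within the scatter; against compound 2 the gap lies beyond it. The difference between the core of compound 1 and the core of compound 3 is not broken down here.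

Compound 4, `CC1(C)CC(NC(=O)Nc2cccc(Cl)c2)c2cc(NS(C)(=O)=O)ccc2O1`, has not been measured. It differs from compound 3 by 3-chlorophenyl in place of 4-cyanophenyl on an amide-type nitrogen. The same kind of change separates compound 1 from compound 2, where (3-chlorophenyl in place of 4-cyanophenyl on an amide-type nitrogen); there the amide-type nitrogen has a thiocarbonyl carbon as its other neighbour, whereas in compound 3 and compound 4 it has a carbonyl carbon. That earlier change produced a 1.2-fold lower number from compound 1 to compound 2 (0.07 log units; within the scatter).

On this single precedent, compound 4 is expected to move by a 1.2-fold lower number from compound 3 to compound 4 (0.08 log units; within the scatter), a step of about the same small size because a 1.2-fold lower number from compound 1 to compound 2 (0.07 log units; within the scatter) stayed within the scatter. In this assay compound 4 is therefore estimated at 16500 nM, with a likely range from 8000 nM to 35000 nM.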

Compound 4, half-maximal effective concentration: 15200 nM
Estimate against measurement, compound 4: 1.1-fold (0.04 log units) above, within the range that was stated.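

The exchange of 4-cyanophenyl for 3-chlorophenyl on the amide-type nitrogen gave a 1.3-fold lower number from compound 3 to compound 4 (0.11 log units; within the scatter) in this assay. Set beside the earlier case, the change read alike whether that nitrogen's other neighbour was a thiocarbonyl carbon or a carbonyl carbon: the same change on two cores in this assay, a 1.2-fold lower number (0.07 log units; within the scatter) from compound 1 to compound 2 and a 1.3-fold lower number (0.11 log units; within the scatter) from compound 3 to compound 4, 1.1-fold (0.04 log units) apart, within the scatter of two such steps. For these two cores, then, the small size of the step carried over from one to the other, but neither step rises above the scatter, so the pairs do not establish a real effect of the change, and two pairs give no rule for other cores or other read-outs.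

The compounds shown leave open how other groups on that nitrogen would read, such as an unsubstituted phenyl, a methoxyphenyl or a longer alkyl chain. They also leave open whether a step beyond the scatter would carry over between the two cores in the same way, and what an amine or a carboxylic acid on the shared core would do.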